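Exchanging the Amine on a Thiocarbonyl Carbon

This account rests on a few compounds, and the source may have more. Where it says the series, first, only, none or still open, it means among the compounds named here.

Compound 1, `O=c1cc(CSC(=S)N2CCCC2)oc2ccccc12`: in a functional assay on SW480 cells (Homo sapiens) for antiproliferative activity, read by MTT assay, with a stated time of 72 h (a higher number here means a weaker inhibitor, a lower number a stronger inhibitor), compound 1 gives 23400 nM.
Compound 2, `CC(C)N(C(=S)SCc1cc(=O)c2ccccc2o1)C(C)C`: in this assay compound 2 gives > 40000 nM, a limit of the assay.

Compound 2 thus stands only at the limit of the assay (the limit of > 40000 nM in this assay, at which 1 of the 2 values shown sits). Compound 3, `O=c1cc(CSC(=S)N2CCOCC2)oc2ccccc12`, differs from it by morpholin-4-yl in place of diisopropylamino on a thiocarbonyl carbon. Going by the values given here, the one measured step bearing on this, an at least 1.7-fold higher number from compound 1 to compound 2 (0.23 log units; that floor lies within the scatter), sits at that floor. Since morpholin-4-yl is again a ring amine like pyrrolidin-1-yl in compound 1, compound 3 is expected to move back toward the value of compound 1, with an at least 1.3-fold lower number from compound 2 to compound 3 (0.12 log units; that floor lies within the scatter). The estimate for compound 3 is 30000 nM, ranging from 10000 nM to 80000 nM.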

Compound 3, half-maximal inhibitory concentration: 24400 nM
The estimate for compound 3 lay 1.2-fold (0.09 log units) above the measured number, within the range that was stated.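

The new result shows that morpholin-4-yl and pyrrolidin-1-yl on a thiocarbonyl carbon cannot be told apart in this assay, with a 1.0-fold higher number from compound 1 to compound 3 (0.02 log units; within the scatter). The comparison with diisopropylamino gives only a floor, an at least 1.6-fold lower number from compound 2 to compound 3 (0.21 log units; that floor lies within the scatter), so it does not separate the ring amines from that open-chain amine. Compound 2 remains a limit of the assay, so this step has no true size: the limit of > 40000 nM in this assay, at which 1 of the 3 values shown sits.

Going by these compounds, whether a piperazine or a dimethylamino group at this place would give a number beyond the scatter remains open.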